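A few compounds are considered here, and "the series" means these few. Any claim that something is new, unique, unknown or untested is made for them only; others in the source may bear on it.

Going by the values given here, compound 1 `N#Cc1c(N2CCC(c3ccccc3)CC2)ccn2c(CC(F)(F)F)nnc12` is one of three compounds measured in a functional assay on CHO cells for positive allosteric modulation of metabotropic glutamate receptor 2 (Homo sapiens), read by GTPgammaS binding, with a stated time of 30 min; on this read-out lower numbers stand for an effect already at smaller amounts and higher numbers for an effect only at larger amounts of compound. Compound 1 gives 56 nM, the lowest of the three numbers. Compound 2 `CC(C)(C)c1nnc2c(C#N)c(N3CCC(c4ccccc4)CC3)ccn12` gives 1230 nM, and compound 3 `N#Cc1c(N2CCC(c3ccccc3)CC2)ccn2c(CN3CCCC3)nnc12` gives 1120 nM. Both steps away from compound 1 are large: a 22-fold higher number from compound 1 to compound 2 (1.34 log units; beyond the scatter) and a 20-fold higher number from compound 1 to compound 3 (1.30 log units; beyond the scatter). Between the two weaker compounds the difference is small, a 1.1-fold lower number from compound 2 to compound 3 (0.04 log units; within the scatter), so they cannot be told apart.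

Compound 4 `FC(F)(F)Cc1nnc2c(Cl)c(N3CCC(c4ccccc4)CC3)ccn12` has not yet been measured. It differs from compound 1 in one place: chloro in place of cyano on an aromatic carbon. Among the compounds with values here, none of the measured steps touches this group. All three measured compounds keep the cyano, and the measured steps change a different part of the shared core. The size of the step to compound 4 therefore cannot be read off the measured steps, and the expectation rests on the swap itself, a small halogen replacing a small nitrile. The step of a 2.0-fold higher number from compound 1 to compound 4 (0.29 log units; within the scatter) is expected to be modest, most likely within or close to the scatter, with some risk of a weaker compound. The estimated number for compound 4 is 110 nM, with a range from 30 nM to 450 nM.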

Compound 4, half-maximal effective concentration: 55 nM
The estimate for compound 4 lay 2.0-fold (0.30 log units) above the measured number; the measured number falls inside the stated range.
By their numbers in this assay, from the lowest: compounds 4 and 1 (each within the scatter of the next); then compounds 3 and 2 (each within the scatter of the next).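

In this assay, the step of a 1.0-fold lower number from compound 1 to compound 4 (0.01 log units; within the scatter) shows that chloro can take the place of cyano on this aromatic carbon with no difference that can be told apart from the scatter. The earlier compounds shown here all carried the cyano, so they could not show this. The new pair also shows that a low number in this series does not depend on the triple bond or the hydrogen-bond acceptor that leave with the cyano, since compound 4, with no such acceptor in the chloro, cannot be separated from compound 1. The large steps seen so far all came from replacing the 2,2,2-trifluoroethyl group, whereas this first change at the cyano position gives no such step, though nothing in hand explains why these two groups give such similar numbers.

Going by these compounds, whether this position also accepts a different group, such as a methyl, a methoxy or a plain hydrogen, remains open. Going by these compounds alone, also open is whether chloro would match cyano alongside tert-butyl or (pyrrolidin-1-yl)methyl, since the one pair here carries 2,2,2-trifluoroethyl on both sides.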